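The compounds below may be only part of what the source reports. "The series", "measured", "known", "first", "only" and "open" are said of these compounds alone.

Measured compounds:
compound 1 `C[Se]c1nc(N)c2ccccc2n1` — > 100000 nM
compound 2 `Nc1nc([SeH])nc2ccccc12` — 52400 nM

In a functional assay on CCRF-CEM cells (Homo sapiens) for cytotoxicity, read by MTT assay, with a stated time of 72 h (on this read-out lower numbers stand for stronger inhibition of growth and higher numbers for weaker inhibition of growth), compound 1 gives > 100000 nM, which is a limit of the assay and not a number. Compound 1 thus sits at the limit of > 100000 nM in this assay, at which 1 of the 2 values shown sits. Compound 2 gives 52400 nM. For the measured compounds named here, the single measured step, an at least 1.9-fold lower number from compound 1 to compound 2 (0.28 log units; that floor lies within the scatter), starts from a limit and so tells little about the true size of any change. Compound 3 `C[Se]c1nc([Se]C)c2ccccc2n1` differs from compound 1 by a group of 2 heavy atoms (1 carbon, 1 selenium; no ring) in place of one nitrogen atom, on an aromatic carbon. Going by the values given here, no measured step covers this change: the step from compound 1 to compound 2 concerns the methyl on selenium, not the amino group. Because compound 1 stands at the limit of > 100000 nM in this assay, at which 1 of the 2 values shown sits, compound 3 is expected to remain at or near that limit, with no step beyond the scatter foreseen. Among the compounds with values here, the expected step that the limit leaves unreadable from compound 1 to compound 3 rests on no measured precedent. Compound 3 is therefore estimated at 150000 nM, within 40000 nM to 600000 nM.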

Compound 3, concentration for total growth inhibition: 54900 nM
For compound 3 the middle estimate is 2.7-fold (0.44 log units) above the measured one; the measured number falls inside the stated range.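

In this assay compound 3 gives a measured number, 54900 nM, so a readable growth inhibition does not require the amino group on this aromatic carbon when a group of 2 heavy atoms (1 carbon, 1 selenium; no ring) stands there instead. The change gives an at least 1.8-fold lower number from compound 1 to compound 3 (0.26 log units; that floor lies within the scatter), which is a floor and not a measured size. Compound 1 remains a limit of the assay, so the true size of the change stays unread: the limit of > 100000 nM in this assay, at which 1 of the 3 values shown sits.

On these data alone, how a methoxy group, a hydroxyl group or a longer chain on selenium would read at this aromatic carbon remains open. Also open, as far as these compounds go, is how much of the result comes from losing the amino group and how much from the selenium-bearing group that enters.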